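Dropping the Cyano Group from Compound 1

The source may hold more compounds than are shown below. What is called first, only, known or untested is meant among the compounds shown, and "the series" means these compounds.

Compound 1 `C/N=C(/S)C1=CC(C)(C)Oc2ccc(C#N)cc21` acts on rat aorta in a functional assay (aorta) with Rattus norvegicus as the target (a higher number here means that more compound is needed for the effect, a lower number that less compound is needed), where compound 1 gives 24.6 nM. Among the two numbers measured so far, that is the highest; the nearest is compound 2 `C/N=C(/S)C1=CC(C)(C)Oc2ccc(C(F)(F)C(F)(F)F)cc21`, which in this assay gives 12.6 nM, a step of a 2.0-fold lower number from compound 1 to compound 2 (0.29 log units; within the scatter). Compound 3 `C/N=C(/S)C1=CC(C)(C)Oc2ccccc21` has not yet been measured. Its difference from compound 1 is hydrogen in place of cyano on an aromatic carbon. Going by the values given here, only one measured step touches the same place, the one from compound 1 to compound 2, and it exchanged one group for another rather than removing it. Among the compounds with values here, no measured compound carries only hydrogen at that position, so the expectation rests on a gap in the data. The step from compound 1 to compound 3 is estimated as a 10-fold higher number from compound 1 to compound 3 (1.01 log units; beyond the scatter), a move toward needing more compound. Compound 3 is therefore expected to give about 250 nM, within a range from 50 nM to 1500 nM.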

Compound 3, half-maximal effective concentration: 4270 nM
Beside the measured number, compound 3's estimate is 17-fold (1.23 log units) below it, and the stated range ends below it.
By their numbers in this assay, from the lowest: compounds 2 and 1 (each within the scatter of the next); then compound 3.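

Replacing cyano with hydrogen on this aromatic carbon gives a 170-fold higher number from compound 1 to compound 3 (2.24 log units; beyond the scatter) in this assay. Replacing 1,1,2,2,2-pentafluoroethyl with hydrogen at the same carbon gives a 340-fold higher number from compound 2 to compound 3 (2.53 log units; beyond the scatter). The earlier exchange of one group for another stayed within the scatter, so only now does it become clear that this position matters: among these three compounds, either group on the shared core goes with far less compound being needed than hydrogen does.

The compounds shown leave open whether a different group here, such as methyl, an amine or a carboxylic acid, would give a number close to those of compounds 1 and 2 or close to that of compound 3. No measurement shown here accounts for the size of these steps.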